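Carbamate in place of thioimidate on a shared nucleoside core

This account rests on a few compounds, and the source may have more. Where it says the series, first, only, none or still open, it means among the compounds named here.

Three compounds share one core and differ only in the group attached to the oxygen on the saturated carbon of the sugar arm. Compound 1 `CCNC(=O)OC[C@H]1OC(n2cnc3c(NC4CCOC4)ncnc32)[C@H](O)[C@@H]1O` carries the smaller carbamate, compound 2 `CCCNC(=O)OC[C@H]1OC(n2cnc3c(NC4CCOC4)ncnc32)[C@H](O)[C@@H]1O` a carbamate one carbon longer, and compound 3 `CCCC/N=C(\S)OC[C@H]1OC(n2cnc3c(NC4CCOC4)ncnc32)[C@H](O)[C@@H]1O` the sulfur-bearing group. In an assay on DDT1 cells (Cricetulus griseus) for binding affinity to adenosine receptor A1 (Homo sapiens), read by radioligand binding (a higher number here means a weaker inhibitor, a lower number a stronger inhibitor), compound 1 gives 167 nM, compound 2 gives 235 nM, and compound 3 gives 157 nM. Compound 3 thus has the lowest of the three numbers, but all three lie within the usual scatter of one another, so no order can be claimed among them.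

Compound 4 `CC(C)NC(=O)OC[C@H]1OC(n2cnc3c(NC4CCOC4)ncnc32)[C@H](O)[C@@H]1O` returns to a carbamate: a group of 6 heavy atoms (4 carbon, 1 nitrogen, 1 oxygen; no ring) in place of a group of 7 heavy atoms (5 carbon, 1 nitrogen, 1 sulfur; no ring), on an oxygen on a saturated carbon. For the measured compounds named here, two measured steps bear on this kind of exchange at the same oxygen. Going from the smaller carbamate to the sulfur group gave a 1.1-fold lower number from compound 1 to compound 3 (0.03 log units; within the scatter), and from the longer carbamate a 1.5-fold lower number from compound 2 to compound 3 (0.18 log units; within the scatter). The branching of the chain has its nearest parallel in a 1.4-fold higher number from compound 1 to compound 2 (0.15 log units; within the scatter). Every step was within the scatter, so the expectation for this assay is a step of no size beyond the scatter, in either direction: a 1.3-fold higher number from compound 3 to compound 4 (0.11 log units; within the scatter). Compound 4 is therefore estimated at 200 nM, within a range from 100 nM to 400 nM.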

Compound 4, inhibition constant: 78 nM
Compound 4: middle estimate off by 2.6-fold (0.41 log units), on the high side; the whole stated range lies above it.
By their numbers in this assay, from the lowest: compounds 4, 3, 1 and 2 (each within the scatter of the next, the first and the last beyond it).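

In this assay, for the compounds shown here, the isopropylcarbamoyl group on this oxygen is the first change to move the number beyond the scatter, with a 3.0-fold lower number from compound 2 to compound 4 (0.48 log units; beyond the scatter) and a 2.1-fold lower number from compound 1 to compound 4 (0.33 log units; beyond the scatter) both modest in size. The earlier carbamates, compound 1 and compound 2, could not be told apart, so chain size alone had shown nothing at this position; the step to compound 4 shows that exchanging propyl for isopropyl on the amide-type nitrogen can register, even though the chain is only rearranged. The sulfur-bearing group of compound 3 is still not separated from this carbamate, since a 2.0-fold lower number from compound 3 to compound 4 (0.30 log units; within the scatter) stays at the edge of the scatter, so the result sets compound 4 apart from the other two carbamates but not from every group at this position.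

Going by these compounds, it remains open whether further branching, as in a tert-butyl carbamate, or a small ring on the nitrogen, as in a cyclopropyl carbamate, would carry the number further in the same direction. Nothing given here offers an explanation for why the branched chain differs from the straight one.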